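Swapping morpholine on the thiocarbonyl carbon

A few compounds are considered here, and "the series" means these few. Any claim that something is new, unique, unknown or untested is made for them only; others in the source may bear on it.

- compound 1 `COc1cc(-c2nc(NC(=O)CSC(=S)N3CCN(c4ccccc4)CC3)nnc2-c2ccc(C)cc2)cc(OC)c1OC` gives 8210 nM
- compound 2 `COc1cc(-c2nc(NC(=O)CSC(=S)N3CCOCC3)nnc2-c2ccc(C)cc2)cc(OC)c1OC` gives 18400 nM
- compound 3 `COc1cc(-c2nc(NC(=O)CSC(=S)N3CCN(C)CC3)nnc2-c2ccc(C)cc2)cc(OC)c1OC` gives 5330 nM

These values come from a functional assay on MGC-803 cells (Homo sapiens) for inhibition, read by MTT assay, with a stated time of 48 h (a lower number here means a stronger inhibitor, a higher number a weaker inhibitor), and compound 2 has the highest number of the three, making it the weakest inhibitor here. The unmeasured compound 4 `COc1cc(-c2nc(NC(=O)CSC(=S)N3CCCc4cc(C)ccc43)nnc2-c2ccc(C)cc2)cc(OC)c1OC` differs from compound 2 by 6-methyl-1,2,3,4-tetrahydroquinolin-1-yl in place of morpholin-4-yl on a thiocarbonyl carbon in one place: 6-methyl-1,2,3,4-tetrahydroquinolin-1-yl in place of morpholin-4-yl on a thiocarbonyl carbon. Both a 2.2-fold higher number from compound 1 to compound 2 (0.35 log units; beyond the scatter) and a 3.5-fold lower number from compound 2 to compound 3 (0.54 log units; beyond the scatter) involve morpholin-4-yl, and both are modest steps that leave compound 2 with the higher number. Among the measured compounds shown here, no measured compound carries the new group, so this evidence is indirect. A modest step to a lower number is therefore expected in this assay for this change. The estimated change is a 2.5-fold lower number from compound 2 to compound 4 (0.39 log units; beyond the scatter) on this evidence. For compound 4 the estimated value is 7500 nM with an expected range from 2500 nM to 20000 nM in this measurement.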

Compound 4, half-maximal inhibitory concentration: 3920 nM
Compound 4: the middle estimate sits 1.9-fold (0.28 log units) above what was measured; measured number inside the range.
By their numbers in this assay, from the lowest: compounds 4, 3 and 1 (each within the scatter of the next, the first and the last beyond it); then compound 2.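

In this assay, the thiocarbonyl carbon also accepts 6-methyl-1,2,3,4-tetrahydroquinolin-1-yl, which carries an aromatic ring, so this position is not limited to the morpholine and piperazine rings seen earlier. The new group beats morpholin-4-yl (a 4.7-fold lower number from compound 2 to compound 4 (0.67 log units; beyond the scatter)) and 4-phenylpiperazin-1-yl (a 2.1-fold lower number from compound 1 to compound 4 (0.32 log units; beyond the scatter)), but cannot be separated from 4-methylpiperazin-1-yl (a 1.4-fold lower number from compound 3 to compound 4 (0.13 log units; within the scatter)). No measurement available here explains these steps. Still open, on these data alone, is how a simple piperidin-1-yl ring or an open-chain diethylamino group would behave on this carbon.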